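This account rests on a few compounds, and the source may have more. Where it says the series, first, only, none or still open, it means among the compounds named here.

Measured so far:
compound 1 `CC(C)n1nc(-c2ccnc3[nH]c(C4CCN(CC(=O)N(C)C)CC4)cc23)ccc1=O` gives 11000 nM in a physicochemical assay for solubility, in phosphate buffer, at pH 7.4; a lower number here means a less soluble compound, a higher number a more soluble compound
compound 2 `CN(C)C(=O)CN1CCC(c2cc3c(-c4ccc(=O)n(CCC5CCOCC5)c4)ccnc3[nH]2)CC1` gives 370000 nM in this assay

Of these two, compound 2 has the higher number, and its gap to compound 1 lies beyond the scatter. Compound 3 `CCn1cc(-c2ccnc3[nH]c(C4CCN(CC(=O)N(C)C)CC4)cc23)ccc1=O` has not been measured yet. It has hydrogen in place of oxan-4-yl on a saturated chain carbon, two bonds along the chain from an aromatic nitrogen, so 2-(oxan-4-yl)ethyl becomes ethyl. For the measured compounds named here, no measured pair differs in one place only, so there is no direct guide to this step. Compound 1, which carries no oxan-4-yl group, sits lower (11000 nM), but it differs from compound 2 in more than one place, so this is only a weak hint. A modest fall in this assay is therefore expected, with the estimated step of a 3.1-fold lower number from compound 2 to compound 3 (0.49 log units; beyond the scatter) being quite uncertain. For compound 3 the estimated value is 120000 nM, with an expected range of 25000 nM to 500000 nM.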

Compound 3, solubility: > 1000000 nM
Compound 3: no number, only a limit (the forecaster's own chance of this, stated with the estimate: 10%); middle value at least 8.3-fold (0.92 log units) away from the limit.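

In this assay, for the compounds shown here, compound 3 gives a limit and not a number: the limit of > 1000000 nM in this assay, at which 1 of the 3 values shown sits. The earlier compounds left the role of the oxan-4-yl group at this position untested, and replacing 2-(oxan-4-yl)ethyl with ethyl now gives an at least 2.7-fold higher number from compound 2 to compound 3 (0.43 log units; beyond the scatter), so a high number here does not depend on that ring. The change of the group on the aromatic carbon, read against the other earlier compound, gives an at least 90-fold higher number from compound 1 to compound 3 (1.95 log units; beyond the scatter), and both steps are only lower bounds whose true size stays hidden by the limit.

Going by these compounds, it remains open whether methyl, a longer plain chain or a chain ending in an amine would also reach this limit. The compounds shown also leave open whether the change from 2-(oxan-4-yl)ethyl to ethyl would run the same way on the core of compound 1.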